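A Methyl-to-Hydrogen Swap Tested on a Second Core

The source may report more compounds than this note shows. Statements on the series, on what has been measured and on what is new or still open speak of the compounds shown alone.

Compound 1 `COc1ccc(/C=C/C(=O)c2ccccc2-c2ccc(F)cc2)cc1OC`: 81 nM
Compound 2 `COc1ccc(/C=C/C(=O)c2ccccc2-c2ccc(F)cc2)cc1O`: 87 nM
Compound 3 `COc1ccc(C(=O)/C=C/c2ccccc2-c2ccc(F)cc2)cc1OC`: 7600 nM

These three compounds were measured in a functional assay on CNE-2 cells (Homo sapiens) for antiproliferative activity, read by sulforhodamine B assay, with a stated time of 48 h; a higher number here means a weaker inhibitor, a lower number a stronger inhibitor. Compound 1 and compound 2 share a core and differ by hydrogen in place of methyl on an oxygen on an aromatic ring; this change gave a 1.1-fold higher number from compound 1 to compound 2 (0.03 log units; within the scatter). Compound 3 is built from the same atoms as compound 1, joined differently; the difference between the two cores is not broken down here. In this assay compound 3 stands far from the other two and gives 7600 nM.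

Compound 4 `COc1cc(C(=O)/C=C/c2ccccc2-c2ccc(F)cc2)ccc1O` is not yet measured. It carries, relative to compound 3, the same change that compound 2 carries relative to compound 1: hydrogen in place of methyl on an oxygen on an aromatic ring. For compound 4 the expected step is a 1.1-fold higher number from compound 3 to compound 4 (0.02 log units; within the scatter), essentially no change, because a 1.1-fold higher number from compound 1 to compound 2 (0.03 log units; within the scatter) lay within the scatter. Compound 4 is therefore estimated to give 8000 nM in this assay, with a likely range from 3000 nM to 20000 nM.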

Compound 4, half-maximal inhibitory concentration: 4800 nM
Estimate against measurement, compound 4: 1.7-fold (0.22 log units) above; the range from low to high includes it.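

The swap of methoxy to hydroxy gave a 1.6-fold lower number from compound 3 to compound 4 (0.20 log units; within the scatter), so on this second core, as on the first, the step in this assay is too small to read, and the two cores do not differ in this respect: the same change on two cores in this assay, a 1.1-fold higher number (0.03 log units; within the scatter) from compound 1 to compound 2 and a 1.6-fold lower number (0.20 log units; within the scatter) from compound 3 to compound 4, 1.7-fold (0.23 log units) apart, within the scatter of two such steps

Within these two pairs, then, the change carries over from one core to the other as a step lost in the scatter. This does not show that the swap would be as silent on any other core, and it says nothing about what separates the two cores themselves.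

The compounds shown leave open what the other methoxy group on each core would do if swapped in the same way. They also leave open what an ethyl group, a longer chain or an amine would do in place of this methoxy.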